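Imidazolyl for tert-butyl on a nitrofuran chalcone

The source may hold more compounds than are shown below. What is called first, only, known or untested is meant among the compounds shown, and "the series" means these compounds.

Three chalcones carry measurements in an ADME assay on Vero cells (Chlorocebus sabaeus) for cytotoxicity, read by resazurin assay, with a stated time of 72 h; on this read-out lower numbers stand for higher toxicity in this test and higher numbers for lower toxicity in this test. Compound 1 `CC(C)(C)c1ccc(C(=O)/C=C/c2ccc([N+](=O)[O-])o2)cc1` gives in this assay only a limit, > 100000 nM. Compound 2 `CCCCc1ccc(C(=O)/C=C/c2ccc([N+](=O)[O-])s2)cc1` gives in this assay 81300 nM. Compound 3 `CN(C)c1ccc(/C=C/C(=O)c2ccc(-c3ccccc3)cc2)cc1` has no result in this assay, reported as "not determined" (no result reported). Among the measured compounds shown here, compound 1 therefore stands at the limit of > 100000 nM in this assay, at which 1 of the 3 values shown sits, and no pair of measured compounds differing in one place exists, so no measured step size is available.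

Compound 4 `O=C(/C=C/c1ccc([N+](=O)[O-])o1)c1ccc(-n2ccnc2)cc1` differs from compound 1 in 1H-imidazol-1-yl in place of tert-butyl on an aromatic carbon. For the measured compounds named here, with no measured pair carrying this change, the step is expected to be an at least 1.1-fold lower number from compound 1 to compound 4 (0.04 log units; that floor lies within the scatter), none beyond the usual scatter. Compound 4 is expected to give about 90000 nM in this assay, within a range from 30000 nM to 300000 nM.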

Compound 4, half-maximal cytotoxic concentration: > 100000 nM
Compound 4 ended at the assay's limit; the forecaster's own chance of this, stated with the estimate: 55%; middle value at least 1.1-fold (0.04 log units) away from the limit.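

No step can be read between compound 1 and compound 4 in this assay, as each gives only a limit: the limit of > 100000 nM in this assay, at which 2 of the 4 values shown sit.

The compounds shown leave open whether 1H-imidazol-1-yl in place of tert-butyl changes the half-maximal cytotoxic concentration at all.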